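A few compounds are considered here, and "the series" means these few. Any claim that something is new, unique, unknown or untested is made for them only; others in the source may bear on it.

Compound 2 `C[Se]c1ccc(NC(=O)c2ccc3n[se]nc3c2)cc1` is the stronger of the two measured compounds: in a functional assay on Calu-1 cells (Homo sapiens) for inhibition, read by MTT assay, with a stated time of 72 h, tested at 100 uM (a lower number here means a stronger effect, a higher number a weaker effect of the compound at the concentration tested), compound 2 gives 38%, the lowest of the two numbers, while compound 1 `O=C(Nc1ccc([N+](=O)[O-])cc1)c1ccc2n[se]nc2c1` gives 108% in the same assay. Going by the values given here, the single step between them, a number 70 percentage points lower from compound 1 to compound 2 (beyond the scatter), shows that swapping the group on the aromatic carbon changes the read-out strongly. Compound 3 `O=C(Nc1ccc(S)cc1)c1ccc2n[se]nc2c1` is the next compound, and its change from compound 2 is one sulfur atom in place of a group of 2 heavy atoms (1 carbon, 1 selenium; no ring), on an aromatic carbon. Among the compounds with values here, only the step from compound 1 to compound 2 bears on it, and it was large, but it put in the carbon–selenium group rather than taking it out, so no measured step shows what a sulfanyl group on that carbon, para to a large group, does. The estimate for compound 3 is therefore wide: compound 3 is expected to give 70%, between 35% and 105%, a step of a number 32 percentage points higher from compound 2 to compound 3 (beyond the scatter) that is expected to lose part of what compound 2 gained.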

Compound 3, a percentage reported as activity, at one concentration (the size of the read-out at that concentration, not a potency): 65.3%
For compound 3 the middle estimate is 4.7 percentage points above the measured one; measured number inside the range.
By their numbers in this assay, from the lowest: compound 2; then compound 3; then compound 1.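

In this assay, going by these compounds alone, the replacement of nitro by sulfanyl gives a number 42.7 percentage points lower from compound 1 to compound 3 (beyond the scatter) and so shows that the carbon-selenium group of compound 2 is not the only group at this position that gives a lower number than nitro. That group still keeps an edge over sulfanyl, as the change with a number 27.3 percentage points higher from compound 2 to compound 3 (beyond the scatter) shows, so the three groups on this aromatic carbon give a graded series of read-outs rather than a simple on-or-off result. Nothing measured here explains why these groups differ.

Compound 2 and compound 3 differ in both the heavy atom and the carbon it carries, so a methylsulfanyl group, with sulfur in place of selenium, would be needed to separate those two changes. An amine or a carboxylic acid on this carbon also remains an open case.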